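The source may report more compounds than this note shows. Statements on the series, on what has been measured and on what is new or still open speak of the compounds shown alone.

Measured in a physicochemical assay for solubility, at pH 7.4; on this read-out higher numbers stand for higher solubility and lower numbers for lower solubility:
- Compound 1 `CCCCCCCc1cn(-c2ccc(CNC(=O)[C@H]3NCC[C@@H]3O)cc2)nn1`: 3.1 ug/mL
- Compound 2 `CCCCCCc1nc(-c2ccc(CNC(=O)[C@H]3NCC[C@@H]3O)cc2)no1`: > 50 ug/mL
- Compound 3 `CC1(c2nc(-c3ccc(CNC(=O)[C@H]4NCC[C@@H]4O)cc3)no2)CCCCC1`: > 50 ug/mL

Compound 3 stands at a limit of the assay and not at a number, and compound 2 shares that position: the limit of > 50 ug/mL in this assay, at which 2 of the 3 values shown sit. Compound 1 gives 3.1 ug/mL, a true number. It differs from compound 2 in more than one place and does not size the change considered here.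

Compound 4 `O=C(NCc1ccc(-c2noc(CCC3CC3)n2)cc1)[C@H]1NCC[C@@H]1O` keeps the core of compound 3 and alters one group: 2-cyclopropylethyl in place of 1-methylcyclohexyl on an aromatic carbon. In words, 2-cyclopropylethyl replaces 1-methylcyclohexyl on an aromatic carbon of a five-membered aromatic ring with 2 nitrogen and 1 oxygen.

Among the compounds with values here, the one measured step at this place is a step that the two limits leave unreadable from compound 2 to compound 3. Both of its ends are limits, so it gives no size to carry over. Still, hexyl and 1-methylcyclohexyl at this place both left the read-out at the limit, and nothing measured points to a fall with 2-cyclopropylethyl. No step beyond the scatter is therefore expected in this assay, and no direction can be named. The estimated move is a step that the limit leaves unreadable from compound 3 to compound 4. For compound 4 the expected value is 60 ug/mL, with an estimated range of 25 ug/mL to 120 ug/mL, and a report as a limit alone is quite likely.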

Compound 4, solubility: > 50 ug/mL
Compound 4 was reported as a limit; the forecaster's own chance of this, stated with the estimate: 70%; the middle value does not contradict the limit.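

In this assay compound 4 gives > 50 ug/mL, a limit of the assay and not a number. No step among compound 2, compound 3 and compound 4 can be read: the limit of > 50 ug/mL in this assay, at which 3 of the 4 values shown sit.

The compounds shown leave open whether hexyl, 1-methylcyclohexyl and 2-cyclopropylethyl differ at all in solubility on this aromatic carbon, and by how much.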